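Triazole series: benzyl in place of hydroxyethyl

The source may hold more compounds than are shown below. What is called first, only, known or untested is meant among the compounds shown, and "the series" means these compounds.

Measured so far:
compound 1 `Cc1ccc(-c2cn(CCCO)nn2)cc1`: > 100000 nM
compound 2 `Cc1ccc(C(O)c2cn(CC3COC(C)(C)O3)nn2)cc1`: > 100000 nM

Two compounds of the series have been run in a functional assay on B16 cells (Mus musculus) for cytotoxicity, read by MTT assay, with a stated time of 48 h; a lower number here means a stronger inhibitor, a higher number a weaker inhibitor. In this assay compound 1 gives > 100000 nM, which is a limit of the assay and not a number. In the same assay compound 2 gives > 100000 nM, likewise a limit. For the measured compounds named here, compound 1 therefore stands at the limit of > 100000 nM in this assay, at which 2 of the 2 values shown sit; neither measured compound can be placed relative to the other, and no step between measured compounds is available to calibrate the series.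

Compound 3 `Cc1ccc(-c2cn(Cc3ccccc3)nn2)cc1` is the next entry. It differs from compound 1 by phenyl in place of 2-hydroxyethyl on a saturated chain carbon bound to an aromatic nitrogen. With both measured values sitting at the limit, nothing in the data points to a direction for this change; the expectation is a step of no size beyond the scatter, and the most likely outcome is a further limit rather than a number. Compound 3 is thus expected to give 100000 nM, with a range of 30000 nM to 300000 nM. The step implied by this estimate is a number no higher from compound 1 to compound 3 (the limit leaves the size open), which is expected to be nil.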

Compound 3, half-maximal inhibitory concentration: > 100000 nM
Compound 3 gave a limit, no number (the forecaster's own chance of this, stated with the estimate: 80%); the middle value sits exactly at the limit.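

In this assay compound 3 gives > 100000 nM, a limit of the assay and not a number. No step can be read from compound 1 to compound 3, since both compounds stand at a limit: the limit of > 100000 nM in this assay, at which 3 of the 3 values shown sit.

The compounds shown leave open whether any change to the shared core yields a readable value.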